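A Second Chloro Group and Cell Killing

The source may hold more compounds than are shown below. What is called first, only, known or untested is meant among the compounds shown, and "the series" means these compounds.

compound 1 `ClCc1ccccc1Cn1cnc2c(Cl)nc(Cl)nc21`: 8510 nM
compound 2 `ClCc1ccccc1Cn1cnc2c(Cl)ncnc21`: 66100 nM
compound 3 `ClCc1cccc(Cn2cnc3ncnc(Cl)c32)c1`: 18600 nM

Of the compounds shown here, three have so far been measured in a functional assay on UACC-257 cells (Homo sapiens) for cytotoxicity, read by sulforhodamine B assay, with a stated time of 48 h; on this read-out higher numbers stand for lower toxicity in this test and lower numbers for higher toxicity in this test. Compound 2 and compound 1 differ in one place, (chloro in place of hydrogen on an aromatic carbon), and this change gave a 7.8-fold lower number from compound 2 to compound 1 (0.89 log units; beyond the scatter). Compound 3 is built from the same atoms as compound 2, joined differently; the difference between the two cores is not broken down here. Compound 3 stands second of the three, with compound 1 nearer to it and compound 2 further away.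

Compound 4 `ClCc1cccc(Cn2cnc3nc(Cl)nc(Cl)c32)c1` has not yet been tested. Among the measured compounds shown here, it differs from compound 3 by chloro in place of hydrogen on an aromatic carbon, which is the same change, at a place described in the same words, as the one from compound 2 to compound 1. For the measured compounds named here, on that basis the step is expected to be a 5.3-fold lower number from compound 3 to compound 4 (0.73 log units; beyond the scatter), somewhat smaller than the earlier one because only a single example, a 7.8-fold lower number from compound 2 to compound 1 (0.89 log units; beyond the scatter), supports it. Compound 4 is therefore estimated to give about 3500 nM in this assay, most likely between 1200 nM and 10000 nM.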

Compound 4, concentration lethal to 50% of the cells: 38900 nM
For compound 4 the middle estimate is 11-fold (1.05 log units) below the measured one; the whole stated range lies below it.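

In this assay, chloro in place of hydrogen on an aromatic carbon gave a 2.1-fold higher number from compound 3 to compound 4 (0.32 log units; beyond the scatter), so on this core the change did not lower the number as it had on the other. Set side by side, the two steps disagree in direction and differ in size: the same change on two cores in this assay, a 7.8-fold lower number (0.89 log units; beyond the scatter) from compound 2 to compound 1 and a 2.1-fold higher number (0.32 log units; beyond the scatter) from compound 3 to compound 4, 16-fold (1.21 log units) apart, beyond the scatter of two such steps. In this series, then, the step seen on one core could not be carried over to the other, but two examples do not show what sets the cores apart or how the change would behave on a further core.

The compounds shown carry only hydrogen or chloro at this place, which leaves open how an amine, a methoxy group or a longer chain there would read in this assay. Also open, going by these compounds, is whether the two steps would still disagree if a hydroxymethyl group stood in place of the chloromethyl group on both cores.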